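The compounds below may be only part of what the source reports. "The series", "measured", "known", "first", "only" and "open" are said of these compounds alone.

Of the compounds shown here, three built on one shared core have been measured in a functional assay (Homo sapiens) for inhibition of Nucleic Acid, tested at 100 uM; on this read-out higher numbers stand for more inhibition at the one concentration tested (going by the name of the read-out) and lower numbers for less inhibition. Compound 1 `Nc1nccc2c1ncn2[C@H]1C[C@H](O)[C@@H](CO)O1` carries an amino group on the core and gives 18%. Compound 2 `OC[C@H]1O[C@@H](n2cnc3c(Cl)nccc32)C[C@@H]1O` carries a chloro group in that place and gives 5%. Compound 3 `CSc1nccc2c1ncn2[C@H]1C[C@H](O)[C@@H](CO)O1` carries a methylsulfanyl group there and gives 36%, the highest of the three numbers: a number 18 percentage points higher from compound 1 to compound 3 (beyond the scatter), and a number 31 percentage points higher from compound 2 to compound 3 (beyond the scatter).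

Compound 4 `OC[C@H]1O[C@@H](n2cnc3cnccc32)C[C@@H]1O` differs from compound 3 in one place: hydrogen in place of methylsulfanyl on an aromatic carbon. Going by the values given here, no measured step takes a group away to leave hydrogen, so the closest guides are the two steps that end at compound 3, which both show that putting methylsulfanyl in place of amino or chloro raised the read-out, once modestly and once by a large margin. Taking methylsulfanyl away again is therefore expected to lower the number, by a step of about a number 28 percentage points lower from compound 3 to compound 4 (beyond the scatter). Compound 4 is expected to give around 8%, within a range from 0% to 25%.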

Compound 4, a percentage reported as inhibition, at one concentration (the size of the read-out at that concentration, not a potency): 6%
For compound 4 the middle estimate is 2 percentage points above the measured one; measured number inside the range.
By their numbers in this assay, from the lowest: compounds 2 and 4 (each within the scatter of the next); then compound 1; then compound 3.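

With hydrogen at this position, on an aromatic carbon next to the ring nitrogen, the series now has a reference point for judging each group in this assay. Methylsulfanyl and amino both count for something against that reference, as the swaps to hydrogen show: a number 30 percentage points lower from compound 3 to compound 4 (beyond the scatter) and a number 12 percentage points lower from compound 1 to compound 4 (beyond the scatter). Chloro does not stand apart from hydrogen, with a number 1 percentage points higher from compound 2 to compound 4 (within the scatter), so the low number of compound 2 reflects a group that adds nothing measurable rather than one that harms the read-out, and no data here explain these differences.

The compounds shown leave open whether a longer sulfur chain such as ethylsulfanyl, or methoxy, would give a higher number than methylsulfanyl. They also leave open how these groups compare in potency, since each was read at one concentration only.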